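The source may report more compounds than this note shows. Statements on the series, on what has been measured and on what is new or still open speak of the compounds shown alone.

Working notes on the series. In a physicochemical assay for lipophilicity, read by HPLC, at pH 7.5 (on this read-out lower numbers stand for lower lipophilicity and higher numbers for higher lipophilicity), compound 2 (`CCOc1ccccc1-c1ccc(-c2nc3cnccc3c(C[C@H](C)C(=O)O)c2C#N)cc1`) gives 2.2. That lies within the scatter of compound 1 (`CC[C@@H](Nc1c(C#N)c(-c2ccc(-c3ncccc3C)cc2)nc2cnccc12)C(N)=O`) at 2, while compound 3 (`CC[C@@H](Nc1c(C#N)c(-c2ccc(-c3ccccc3N(C)C)cc2)nc2cnccc12)C(N)=O`) at 3.2 stands beyond the scatter on the higher side.

Compound 4 (`CCCCC(Nc1c(C#N)c(-c2ccc(-c3ccccc3OCC)cc2)nc2cnccc12)C(N)=O`) departs from compound 2 by one replacement: a group of 9 heavy atoms (6 carbon, 2 nitrogen, 1 oxygen; no ring) in place of a group of 6 heavy atoms (4 carbon, 2 oxygen; no ring), on an aromatic carbon. The 2-carboxypropyl group leaves a carbon that is ortho to a cyano group and opposite the ring nitrogen.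

Among the measured compounds shown here, no measured step covers a replacement at this place. For the measured compounds named here, the only step available is a number 1.20 log units higher from compound 1 to compound 3 (beyond the scatter), which is large and falls at a different place, with 2-(dimethylamino)phenyl in place of 3-methylpyridin-2-yl. It shows that the other varied place can carry a large change on its own, since compound 1 and compound 3 share a similar group at the place changing here. At that other place, compound 4 looks more like compound 3, which reads 3.2, than compound 1. Going by the values given here, its entering group is also similar to, though not identical with, the one in compound 3.

An upward move beyond the scatter is therefore expected, estimated as a number 1.40 log units higher from compound 2 to compound 4 (beyond the scatter) in this assay. The expected value for compound 4 is 3.6, with an estimated range from 2.9 to 4.3.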

Compound 4, distribution coefficient: 3.6
The estimate for compound 4 equals the measured number at the digits printed, and the stated range covers the measured number.
By their numbers in this assay, from the lowest: compounds 1 and 2 (each within the scatter of the next); then compound 3; then compound 4.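

Among the compounds shown here, the replacement of 2-carboxypropyl by the group of 9 heavy atoms gives a number 1.40 log units higher from compound 2 to compound 4 (beyond the scatter) in this assay, the first step that can be read at this place, on an aromatic carbon ortho to a cyano group and opposite the ring nitrogen. For the compounds shown here, it shows that this place can carry a large change on its own, whereas the earlier compounds showed one only at a different place, a number 1.20 log units higher from compound 1 to compound 3 (beyond the scatter). No evidence is available on what lies behind the new step, which stands here as a measured difference only.

The compounds shown leave open which feature of the exchange goes with the step: the entering and leaving groups differ together in heavy atoms, in hydrogen-bond donors and acceptors, and in the defined stereocentre, which only the leaving group has. Groups that change one feature at a time at this place, such as a carboxylic acid in place of the primary amide on the same chain, a shorter or longer chain, or a single defined stereoisomer of the entering group, would be needed to separate these features.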